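This account rests on a few compounds, and the source may have more. Where it says the series, first, only, none or still open, it means among the compounds named here.

Measured compounds in an ADME assay on L02 cells (Homo sapiens) for cytotoxicity, read by MTT assay, with a stated time of 48 h; on this read-out lower numbers stand for stronger inhibition and higher numbers for weaker inhibition:

Compound 1 `COC(=O)CC1CCN(C[C@H]2CN(c3ccc(-n4cc(-c5ccccn5)cn4)c(F)c3)C(=O)O2)CC1` — compound 1 gives > 400 ug/mL, which is a limit of this assay.
Compound 2 `COC[C@H]1CN(c2ccc(-n3cc(-c4ccccn4)cn3)c(F)c2)C(=O)O1` — compound 2 gives > 400 ug/mL, again a limit of this assay and not a number.
Compound 3 `O=C1O[C@@H](Cn2ccnc2)CN1c1ccc(-n2cc(-c3ccccn3)cn2)c(F)c1` — compound 3 gives 350 ug/mL.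

Compound 3 is thus the only one of the three with an actual number; the other two sit at the limit of > 400 ug/mL in this assay, at which 2 of the 3 values shown sit. The step that the two limits leave unreadable from compound 1 to compound 2 cannot be read, as both ends are limits. Among the compounds with values here, the two steps that reach compound 3, an at least 1.1-fold lower number from compound 1 to compound 3 (0.05 log units; that floor lies within the scatter) and an at least 1.1-fold lower number from compound 2 to compound 3 (0.05 log units; that floor lies within the scatter), each have a floor that lies within the usual scatter, so none of the measured steps shows a change that can be called real.

Compound 4 `O=C1O[C@@H](Cn2ccnn2)CN1c1ccc(-n2cc(-c3ccccn3)cn2)c(F)c1` differs from compound 3 by 1H-1,2,3-triazol-1-yl in place of 1H-imidazol-1-yl on a saturated chain carbon bound to a saturated ring carbon. Within the data shown here, no measured step swaps one small aromatic ring for another of this kind, so the measured steps give no direction. The expectation is therefore a step of no change at the digits printed from compound 3 to compound 4 (within the scatter) that stays within the scatter, with a fair chance that this assay again reports only a limit. Compound 4 is estimated at 350 ug/mL, with a range from 200 ug/mL to 500 ug/mL.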

Compound 4, half-maximal inhibitory concentration: 49 ug/mL
For compound 4 the middle estimate is 7.1-fold (0.85 log units) above the measured one; measured number below the stated range.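

In this assay, within the data shown here, 1H-1,2,3-triazol-1-yl in place of 1H-imidazol-1-yl gives a 7.1-fold lower number from compound 3 to compound 4 (0.85 log units; beyond the scatter), the first step that can be called real, and here a lower number means stronger inhibition of these cells. The two rings have the same count of heavy atoms and differ only by one ring carbon exchanged for a ring nitrogen, so a small swap on this saturated chain carbon is enough to move the number. The other two steps are an at least 8.1-fold lower number from compound 2 to compound 4 (0.91 log units; beyond the scatter) and an at least 8.1-fold lower number from compound 1 to compound 4 (0.91 log units; beyond the scatter), and both are only floors because compound 1 and compound 2 each give a limit and not a number: the limit of > 400 ug/mL in this assay, at which 2 of the 4 values shown sit.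

The compounds shown do not tell whether the lower number follows the count of ring nitrogens or where those nitrogens stand. A 1H-1,2,4-triazol-1-yl or a 1H-tetrazol-1-yl group at this place would separate those two readings.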